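Coumarin-3-carboxanilides as factor XII inhibitors: methyl variations

A few compounds are considered here, and "the series" means these few. Any claim that something is new, unique, unknown or untested is made for them only; others in the source may bear on it.

Measured so far:
compound 1 `O=C(Nc1ccccc1)c1cc2ccccc2oc1=O` gives 42000 nM
compound 2 `Cc1ccc2oc(=O)c(C(=O)Nc3ccccc3)cc2c1` gives 23000 nM
compound 3 `O=C(Nc1ccccc1)c1cc2cc(Cl)cc(Br)c2oc1=O` gives 4400 nM

In an assay on isolated protein for inhibition of coagulation factor XII (Homo sapiens) (a lower number here means a stronger inhibitor, a higher number a weaker inhibitor), compound 1 gives 42000 nM. Compound 2 carries one change against compound 1, (methyl in place of hydrogen on an aromatic carbon), and in this assay compound 2 gives 23000 nM. The step is a 1.8-fold lower number from compound 1 to compound 2 (0.26 log units; within the scatter); the two values therefore cannot be placed in an order. Compound 3 gives 4400 nM, the lowest number of the three, and its distance from both compound 1 and compound 2 lies beyond the scatter. How the core of compound 3 differs from the core of compound 1 is not broken down here.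

Compound 4 `Cc1cccc(NC(=O)c2cc3cc(Cl)cc(Br)c3oc2=O)c1` has not yet been measured. It differs from compound 3 by methyl in place of hydrogen on an aromatic carbon. Going by the values given here, this is the same kind of change as the one from compound 1 to compound 2, but not the same: there the methyl enters on a six-membered aromatic ring of carbon only that is part of a fused system of two rings, meta to a fused ring and para to a fused ring, whereas here it enters on a six-membered aromatic ring of carbon only, meta to a large group. Among the compounds with values here, only one earlier step of this kind exists, and it stayed within the scatter, so the expectation for compound 4 rests on that single step from compound 1 to compound 2 and on the value of compound 3. The step expected from compound 3 to compound 4 is a 1.3-fold lower number from compound 3 to compound 4 (0.10 log units; within the scatter), a step that should stay within the usual scatter. Compound 4 is therefore estimated at 3500 nM, with a likely range from 1500 nM to 8000 nM.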

Compound 4, half-maximal inhibitory concentration: 10000 nM
The estimate for compound 4 lay 2.9-fold (0.46 log units) below the measured number; measured number outside the range, above it.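

In this assay, methyl in place of hydrogen on the phenyl ring of compound 3 gives a 2.3-fold higher number from compound 3 to compound 4 (0.36 log units; beyond the scatter), a modest step but one beyond the scatter, so compound 4 is the weaker inhibitor of the pair. Set beside the earlier step, this change does not carry over from one core to the other with a single size or direction: the same change on two cores in this assay, a 1.8-fold lower number (0.26 log units; within the scatter) from compound 1 to compound 2 and a 2.3-fold higher number (0.36 log units; beyond the scatter) from compound 3 to compound 4, 4.2-fold (0.62 log units) apart, beyond the scatter of two such steps

This does not show that the core alone sets the outcome, since the two methyl groups also enter at different places, one on the fused ring system of the core and the other on the phenyl ring, and two steps cannot separate these influences or support a general rule for the series.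

The shown compounds leave open how the phenyl to 3-methylphenyl change behaves on the unhalogenated core of compound 1, and how a methyl group behaves at the core position of compound 2 when the chlorine and bromine of compound 3 are present. Also open, as far as these compounds go, is whether another group at the place taken by methyl in compound 4, such as a methoxy group, an amine or a carboxylic acid, would give a lower or a higher number than the phenyl ring of compound 3.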